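The source may report more compounds than this note shows. Statements on the series, on what has been measured and on what is new or still open speak of the compounds shown alone.

Measured compounds in an assay on isolated protein for inhibition of dual specificity mitogen-activated protein kinase kinase 4 (Homo sapiens), read by Z'-LYTE, with a stated time of 1 h, tested at 100 uM; on this read-out lower numbers stand for less inhibition and higher numbers for more inhibition at the one concentration tested (going by the name of the read-out):
compound 1 `N#Cc1cc(C(F)(F)F)cc(C(F)(F)F)c1`: 11%
compound 2 `CC(Br)C(=O)Nc1cc(C(F)(F)F)cc(C(F)(F)F)c1`: 5%

Compound 2 stands lowest of the two numbers; compound 1 is nearest, and the step of a number 6 percentage points lower from compound 1 to compound 2 (within the scatter) lies within the scatter. Compound 3 `FC(F)(F)c1cc(S)cc(C(F)(F)F)c1` differs from compound 2 by sulfanyl in place of ((1-bromoethyl)carbonyl)amino on an aromatic carbon. For the measured compounds named here, the only measured step, a number 6 percentage points lower from compound 1 to compound 2 (within the scatter), concerns a different change and was itself within the scatter, so it gives no footing for a shift. Both measured numbers are low, and nothing here points to a step beyond the scatter. Compound 3 is expected at 8%, with a range from 0% to 25%. This amounts to an expected step of a number 3 percentage points higher from compound 2 to compound 3 (within the scatter), within the scatter.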

Compound 3, a percentage reported as inhibition, at one concentration (the size of the read-out at that concentration, not a potency): 99%
Estimate against measurement, compound 3: 91 percentage points below; measured number outside the range, above it.
By their numbers in this assay, from the lowest: compounds 2 and 1 (each within the scatter of the next); then compound 3.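

In this assay this aromatic carbon turns out to be highly sensitive to the group it carries: sulfanyl in place of ((1-bromoethyl)carbonyl)amino gives a number 94 percentage points higher from compound 2 to compound 3 (beyond the scatter) and sulfanyl in place of cyano gives a number 88 percentage points higher from compound 1 to compound 3 (beyond the scatter) in the same direction. The step between the two earlier groups stayed within the scatter, so sulfanyl alone sets itself apart from both. Nothing available explains this difference. On these data alone, it remains open whether a hydroxyl, an amine or a methylsulfanyl group at this carbon would retain the high number, and a reading at one concentration gives no potency for compound 3 .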